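This account rests on a few compounds, and the source may have more. Where it says the series, first, only, none or still open, it means among the compounds named here.

The measured compounds:
compound 1 `O=S(=O)(NCCCNCc1ccccc1)c1cc(C(F)(F)F)cc(C(F)(F)F)c1`, giving 15000 nM in a functional assay on HT-29 cells (Homo sapiens) for inhibition, read by MTT assay, with a stated time of 72 h; on this read-out lower numbers stand for stronger inhibition of growth and higher numbers for weaker inhibition of growth;
compound 2 `COc1ccc(CNCCCNS(=O)(=O)c2cc(C(F)(F)F)cc(C(F)(F)F)c2)cc1`, giving 2900 nM in this assay.

Going by the values given here, compound 2 stands at the lowest of the two numbers in this assay; its only neighbour is compound 1, and the step between them, a 5.2-fold lower number from compound 1 to compound 2 (0.71 log units; beyond the scatter), is modest but beyond the scatter. Compound 3 `O=S(=O)(NCCCNCc1cccc(Cl)c1)c1cc(C(F)(F)F)cc(C(F)(F)F)c1` has not been measured. It differs from compound 2 by 3-chlorophenyl in place of 4-methoxyphenyl on a saturated chain carbon bound to an amine nitrogen. Among the compounds with values here, the single measured step bears on this change only in part: read in reverse, a 5.2-fold lower number from compound 1 to compound 2 (0.71 log units; beyond the scatter) shows what the loss of the methoxy group costs, while nothing measured tells what the chlorine of the entering 3-chlorophenyl contributes. A step of a 2.1-fold higher number from compound 2 to compound 3 (0.32 log units; beyond the scatter) toward weaker inhibition is therefore expected, smaller than a full return to the number of compound 1. For compound 3 in this assay the estimate is 6000 nM, with a range from 1800 nM to 20000 nM.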

Compound 3, concentration for 50% growth inhibition: 14000 nM
Compound 3: middle estimate off by 2.3-fold (0.37 log units), on the low side; the range from low to high includes it.
By their numbers in this assay, from the lowest: compound 2; then compounds 3 and 1 (each within the scatter of the next).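

In this assay, the exchange of 4-methoxyphenyl for 3-chlorophenyl gives a 4.8-fold higher number from compound 2 to compound 3 (0.68 log units; beyond the scatter), while chloro in place of hydrogen on the aromatic carbon gives a 1.1-fold lower number from compound 1 to compound 3 (0.03 log units; within the scatter). Going by these compounds alone, the chlorine of compound 3 therefore leaves the number within the scatter of that of the unsubstituted compound 1, something the earlier compounds could not show. Of the two substituted rings, only the 4-methoxyphenyl of compound 2 goes with a lower number than compound 1. Nothing available offers an explanation for this difference.

The compounds shown leave open whether the lower number of compound 2 follows the methoxy group itself or the place it occupies on the ring. From the compounds shown here alone, it also remains open whether an ethoxy or a hydroxy group in its stead would keep that number.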